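The compounds below may be only part of what the source reports. "The series", "measured", "known", "first", "only" and "open" are said of these compounds alone.

Of the compounds shown here, three sharing one core have been read in a functional assay on A549 cells (Homo sapiens) for inhibition, read by MTT assay, with a stated time of 72 h; a lower number here means a stronger inhibitor, a higher number a weaker inhibitor. Compound 1 (`CC(C)(C)n1cc2c(n1)C(=O)CC1(CCN(C(=O)c3cc(-c4ccccc4Cl)nc4ccccc34)CC1)O2`), carrying 2-chlorophenyl, gives 2180 nM in this read-out. Compound 2 (`COc1ccc(-c2cc(C(=O)N3CCC4(CC3)CC(=O)c3nn(C(C)(C)C)cc3O4)c3ccccc3n2)cc1OC`), carrying 3,4-dimethoxyphenyl in the same place, gives 2030 nM here, and a 1.1-fold lower number from compound 1 to compound 2 (0.03 log units; within the scatter) separates the pair. Compound 3 (`CCOc1cc(C(=O)N2CCC3(CC2)CC(=O)c2nn(C(C)(C)C)cc2O3)c2ccccc2n1`), carrying ethoxy there, is reported only as a limit, > 10000 nM and no number. Its standing is thus the limit of > 10000 nM in this assay, at which 1 of the 3 values shown sits, and nothing finer.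

Compound 4 (`CC(C)Oc1cc(C(=O)N2CCC3(CC2)CC(=O)c2nn(C(C)(C)C)cc2O3)c2ccccc2n1`) follows from compound 3 by one change, methyl in place of hydrogen on a saturated chain carbon bound to an oxygen on an aromatic ring and a saturated chain carbon (ethoxy to isopropoxy). For the measured compounds named here, no measured step is of this same kind. The nearest evidence is the replacement of an aryl group by ethoxy: an at least 4.5-fold higher number from compound 1 to compound 3 (0.66 log units; beyond the scatter) and an at least 4.9-fold higher number from compound 2 to compound 3 (0.69 log units; beyond the scatter) are both beyond the scatter, and both rest on the limit of compound 3 (> 10000 nM) rather than on a number. Going by the values given here, they show only that the ethoxy compound lies on the weak side of the two aryl compounds. For the addition of one methyl, no step beyond the scatter is expected, and no direction can be read from a limit.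

The expected step, a step that the limit leaves unreadable from compound 3 to compound 4 as estimated, is therefore small. For compound 4 the estimated value is 12000 nM within a range of 5000 nM to 30000 nM and a report as a limit is the likelier outcome.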

Compound 4, half-maximal inhibitory concentration: > 10000 nM
Compound 4: a limit, no number (the forecaster's own chance of this, stated with the estimate: 75%); the middle value is on the limit's open side.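

In this assay, going by these compounds, isopropoxy on this aromatic carbon falls on the weak side of both aryl compounds, as ethoxy did, with an at least 4.9-fold higher number from compound 2 to compound 4 (0.69 log units; beyond the scatter) and an at least 4.5-fold higher number from compound 1 to compound 4 (0.66 log units; beyond the scatter); both steps rest on a limit rather than a number, so their true sizes remain unknown. This extends the finding from one small ether at this position to two, so neither ether tested here gives a measurable value in this read-out, while both aryl groups do. The added methyl itself cannot be assessed, as the step from compound 3 to compound 4 cannot be read with both compounds reported only as limits, and the series now has a second compound at the ceiling: the limit of > 10000 nM in this assay, at which 2 of the 4 values shown sit.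

On these data alone, how far compound 3 and compound 4 lie past that limit, and so whether the methyl changes anything at all, remains open. Also open, as far as these compounds go, is whether a different group on this carbon, such as an amine, a longer ether chain or an unsubstituted phenyl, would return a number and show what this position requires.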